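Solubility notes: indazole to indole exchange, compound 2 to 4

This account rests on a few compounds, and the source may have more. Where it says the series, first, only, none or still open, it means among the compounds named here.

The series is followed in a physicochemical assay for solubility; on this read-out higher numbers stand for higher solubility and lower numbers for lower solubility. Compound 1 `CNC(=O)c1cc(C(=O)NC2CC2)cn(Cc2cccc3[nH]c(C)nc23)c1=O` is reported only as a limit of the assay, >= 198 ug/mL. Compound 2 `CNC(=O)c1cc(C(=O)NC2CC2)cn(Cc2cccc3cn[nH]c23)c1=O` likewise returns a limit rather than a number, >= 181 ug/mL. Compound 3 `CNC(=O)c1cc(C(=O)NCCC(C)C)cn(Cc2ccccc2)c1=O` gives a plain number in this assay, 10 ug/mL. Compound 2 therefore stands at the upper edge of what this assay resolves, together with the other limit, with compound 3 far below both.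

Compound 4 `CNC(=O)c1cc(C(=O)NC2CC2)cn(Cc2cccc3cc[nH]c23)c1=O` is not yet measured. It differs from compound 2 in one place: 1H-indol-7-yl in place of 1H-indazol-7-yl on a saturated chain carbon bound to an aromatic nitrogen. For the measured compounds named here, no measured pair isolates this change, so nothing in the data fixes its size. Since compound 2 is known only as a limit, its true value may lie anywhere above it, and the step from it cannot be read in full. The expected step of an at least 1.6-fold lower number from compound 2 to compound 4 (0.21 log units; that floor lies within the scatter) is a modest fall in this assay, possibly within the usual scatter. For compound 4 the estimate in this assay is 110 ug/mL, within 40 ug/mL to 200 ug/mL.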

Compound 4, solubility: >= 144 ug/mL
Compound 4 ended at the assay's limit; the forecaster's own chance of this, stated with the estimate: 35%; at least 1.3-fold (0.11 log units) between middle value and limit.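

For the compounds shown here, compound 2 and compound 4 are both reported only as limits in this assay, so no step between them can be read. The compounds shown leave open how far apart their true values lie, and whether 1H-indol-7-yl in place of 1H-indazol-7-yl shifts the read-out at all.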